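Compound 3 to compound 4: a methyl group

The source may hold more compounds than are shown below. What is called first, only, known or untested is meant among the compounds shown, and "the series" means these compounds.

In a functional assay on MCF7 cells (Homo sapiens) for antiproliferative activity, read by MTT assay, with a stated time of 48 h (a higher number here means a weaker inhibitor, a lower number a stronger inhibitor), compound 3 (`O=C(/C=C/c1ccccc1)Nc1nnc(-c2ccc(Br)cc2)s1`) gives 1.5 ug/mL, within the scatter of compound 2 (`O=C(/C=C/c1ccc(F)cc1)Nc1nnc(-c2ccc(Br)cc2)s1`) at 1.49 ug/mL. Compound 1 (`COc1ccc(-c2nnc(NC(=O)/C=C/c3ccc(C)cc3)s2)cc1`) gives 0.31 ug/mL, a lower number than compound 3 shows, and the gap between the two lies beyond the scatter. Compound 4 (`Cc1ccc(/C=C/C(=O)Nc2nnc(-c3ccc(Br)cc3)s2)cc1`) differs from compound 3 by methyl in place of hydrogen on an aromatic carbon. Among the measured compounds shown here, the only measured single-place change is a 1.0-fold higher number from compound 2 to compound 3 (0.00 log units; within the scatter), a small step that swaps fluoro for hydrogen on an aromatic carbon. Compound 1 differs from compound 3 in more than one place and isolates no methyl effect. No shift beyond the scatter is therefore expected, and the estimated change is a 1.3-fold lower number from compound 3 to compound 4 (0.10 log units; within the scatter). For compound 4 the expected value is 1.2 ug/mL, with an estimated range of 0.45 ug/mL to 3 ug/mL.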

Compound 4, half-maximal inhibitory concentration: 1.32 ug/mL
Compound 4: the middle estimate sits 1.1-fold (0.04 log units) below what was measured, and the stated range covers the measured number.
By their numbers in this assay, from the lowest: compound 1; then compounds 4, 2 and 3 (each within the scatter of the next).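

In this assay, methyl at this position does not separate from hydrogen or fluoro: a 1.1-fold lower number from compound 3 to compound 4 (0.06 log units; within the scatter) and a 1.1-fold lower number from compound 2 to compound 4 (0.05 log units; within the scatter). Compound 4 also provides the first single-place link to compound 1, and a 4.3-fold higher number from compound 1 to compound 4 (0.63 log units; beyond the scatter) ties that gap to the change of bromo for methoxy, not to the methyl. No measurement at hand explains either result.

On these data alone, whether an amine, a carboxylic acid or a longer chain at this position would shift the number remains open. Also open, as far as these compounds go, is whether methoxy in place of bromo gives a similar step with hydrogen or fluoro at this position.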